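Fluorine on the benzyl arm: predicting cytotoxicity for compound 4

This account rests on a few compounds, and the source may have more. Where it says the series, first, only, none or still open, it means among the compounds named here.

Of the compounds shown here, three sharing one core have been measured in an ADME assay on HepG2 cells (Homo sapiens) for cytotoxicity, read by luminescence, CellTiter-Glo and ATP content, with a stated time of 72 h; on this read-out higher numbers stand for an effect only at larger amounts of compound and lower numbers for an effect already at smaller amounts. Compound 1 `COc1cccc(CNCCCNc2ccnc3cc(Cc4ccccc4)ccc23)c1O` gives 5720 nM. Compound 2 `COc1cccc(CNCCCNc2ccnc3cc(Oc4ccc(F)cc4)ccc23)c1O` gives 11000 nM, and the step of a 1.9-fold higher number from compound 1 to compound 2 (0.28 log units; within the scatter) is within the scatter. Compound 3 `CCC(CC)c1ccc2c(NCCCNCc3cccc(OC)c3O)ccnc2c1` gives 410 nM, the lowest of the three numbers; the steps of a 14-fold lower number from compound 1 to compound 3 (1.14 log units; beyond the scatter) and a 27-fold lower number from compound 2 to compound 3 (1.43 log units; beyond the scatter) are both beyond the scatter, so compound 3 stands clearly apart from the other two.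

Compound 4 `COc1cccc(CNCCCNc2ccnc3cc(Cc4ccc(F)cc4)ccc23)c1O` has not yet been measured. It differs from compound 3 in one place: 4-fluorobenzyl in place of pentan-3-yl on an aromatic carbon.

For the measured compounds named here, the step from compound 3 to compound 4 is nearly the reverse of the step from compound 1 to compound 3, since compound 4 carries a benzyl group that differs from the one in compound 1 only by its fluorine. The step of a 14-fold lower number from compound 1 to compound 3 (1.14 log units; beyond the scatter) was large, and the step of a 1.9-fold higher number from compound 1 to compound 2 (0.28 log units; within the scatter) shows that adding a fluorine to an aromatic ring in this position changed little. Compound 4 is therefore expected to fall near compound 1, with a large upward step a 15-fold higher number from compound 3 to compound 4 (1.17 log units; beyond the scatter). The number for compound 4 in this assay is estimated at 6000 nM, with a range from 2500 nM to 15000 nM.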

Compound 4, half-maximal effective concentration: 4780 nM
Compound 4: middle estimate off by 1.3-fold (0.10 log units), on the high side, and the stated range covers the measured number.
By their numbers in this assay, from the lowest: compound 3; then compounds 4, 1 and 2 (each within the scatter of the next, the first and the last beyond it).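

In this assay, for the compounds shown here, the step of a 1.2-fold lower number from compound 1 to compound 4 (0.08 log units; within the scatter) is the first direct reading of fluoro in place of hydrogen on the benzyl ring, and it shows no change that can be told from repeat measurement. The step of a 12-fold higher number from compound 3 to compound 4 (1.07 log units; beyond the scatter) shows that pentan-3-yl also stands apart from 4-fluorobenzyl, so at this position it now differs by a large step from all three aromatic groups shown: benzyl, 4-fluorophenoxy and 4-fluorobenzyl. The step of a 2.3-fold lower number from compound 2 to compound 4 (0.36 log units; beyond the scatter) adds a modest separation between the two fluorinated groups, even though a 1.9-fold higher number from compound 1 to compound 2 (0.28 log units; within the scatter) had not separated 4-fluorophenoxy from plain benzyl.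

On these data alone, whether the low number belongs to pentan-3-yl alone or would also appear with another group on this aromatic carbon, such as a longer chain, a cyclohexyl ring or an amine, remains open. Nothing available here accounts for the separation of compound 3 from the other compounds.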